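The source may report more compounds than this note shows. Statements on the series, on what has been measured and on what is new or still open speak of the compounds shown alone.

Measured so far in an assay on HeLa cells for binding affinity to 5-hydroxytryptamine receptor 6 (Homo sapiens); a higher number here means a weaker inhibitor, a lower number a stronger inhibitor:

Compound 1, `COc1ccc(NS(=O)(=O)c2ccc3c(Cl)cccc3c2)cc1N1CCN(C)CC1`, gives 0.794 nM in this assay.
Compound 2, `COc1ccc(NS(=O)(=O)c2ccc(Br)cc2)cc1N1CCN(C)CC1`, gives 5.01 nM in this assay.

Compound 2 stands at the higher of the two numbers obtained in this assay. Going by the values given here, the only comparison available is with compound 1, whose number is lower by a margin that lies beyond the usual scatter; the two compounds differ in more than one place, so this gap is read only as what the two values show, not as a single step.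

Compound 3, `COc1ccc(NS(=O)(=O)c2cccc(I)c2)cc1N1CCN(C)CC1`, has not been measured. It differs from compound 2 in one place: 3-iodophenyl in place of 4-bromophenyl on a sulfonyl sulfur. Among the compounds with values here, no step between two measured compounds covers an exchange of this kind, so there is no precedent for its size or direction.

Within the data shown here, with no such precedent, the step from compound 2 to compound 3 is expected to be small, a 1.1-fold lower number from compound 2 to compound 3 (0.05 log units; within the scatter), and not clearly beyond the scatter in either direction. For compound 3 the value in this assay is accordingly estimated at 4.5 nM, with a range from 1.2 nM to 16 nM.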

Compound 3, inhibition constant: 0.794 nM
Compound 3: the middle estimate sits 5.7-fold (0.75 log units) above what was measured; the measured number lies below the stated range.
By their numbers in this assay, from the lowest: compounds 1 and 3 (each within the scatter of the next); then compound 2.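

On the sulfonyl sulfur, the exchange of 4-bromophenyl for 3-iodophenyl gives the series its first readable single-place step in this assay: a 6.3-fold lower number from compound 2 to compound 3 (0.80 log units; beyond the scatter). This position therefore responds to a change that leaves the heavy-atom count of the group, its single carbon-only aromatic ring and its lack of net charge as they were, so those counted features alone do not fix the value in this assay. The change alters both the halogen and the name-position of the substituent at once, and no evidence is available that explains the step or assigns it to either alteration.

The compounds shown leave open whether the step follows the iodine, the 3-substitution or the two together, a question that 3-bromophenyl and 4-iodophenyl on the same sulfonyl sulfur would separate. They also leave open whether a halogen is needed at all, since unsubstituted phenyl, 3-methoxyphenyl or 3-aminophenyl at this place could show how much of the value in this assay depends on it.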